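Hydroxyphenyl Placement and Inhibition in HeLa Cells

A few compounds are considered here, and "the series" means these few. Any claim that something is new, unique, unknown or untested is made for them only; others in the source may bear on it.

Compound 1 `Oc1cccc(-c2cc(-c3cccc(F)c3)cc(-c3ccccc3O)n2)c1` in a functional assay on HeLa cells (Homo sapiens) for inhibition (a lower number here means a stronger inhibitor, a higher number a weaker inhibitor), gives > 50000 nM, which is a limit of the assay and not a number.
Compound 2 `Oc1ccc(-c2cc(-c3cccc(F)c3)cc(-c3ccccc3O)n2)cc1` in this assay gives > 50000 nM, again a limit rather than a number.
Compound 3 `Oc1ccc(-c2cc(-c3cccc(OC(F)(F)F)c3)cc(-c3cccc(O)c3)n2)cc1` in this assay gives 14100 nM.

Compound 1 and compound 2 share a core and differ only by 4-hydroxyphenyl in place of 3-hydroxyphenyl on an aromatic carbon. The step between them, a step that the two limits leave unreadable from compound 1 to compound 2, cannot be sized because of the limit of > 50000 nM in this assay, at which 2 of the 3 values shown sit. Within the data shown here, compound 3 differs from compound 1 in more than one place, and the difference between the two cores is not broken down here; compound 3 is the only compound of the three with a numerical value in this assay.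

Compound 4 `Oc1ccc(-c2cc(-c3cccc(OC(F)(F)F)c3)cc(-c3ccc(O)cc3)n2)cc1` has not yet been measured. It differs from compound 3 by 4-hydroxyphenyl in place of 3-hydroxyphenyl on an aromatic carbon. This is the same kind of change as that from compound 1 to compound 2, not the same change: in compound 1 the carbon carrying the group is meta to a 2-hydroxyphenyl group and meta to a 3-fluorophenyl group, whereas in compound 3 it is meta to a 4-hydroxyphenyl group and meta to a large group.

Since the earlier step is unreadable, nothing in the measured pair says how large the present step will be. The step from compound 3 to compound 4 is therefore expected to be small, a 1.0-fold lower number from compound 3 to compound 4 (0.00 log units; within the scatter), resting only on compound 3 at 14100 nM as the starting point. Compound 4 is estimated to give 14000 nM in this assay, most likely between 4000 nM and 45000 nM.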

Compound 4, half-maximal inhibitory concentration: > 50000 nM
Compound 4 gave a limit, no number; the forecaster's own chance of this, stated with the estimate: 25%; at least 3.5-fold (0.55 log units) between middle value and limit.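

In this assay, from the compounds shown here alone, 4-hydroxyphenyl in place of 3-hydroxyphenyl on the core of compound 3 gives an at least 3.5-fold higher number from compound 3 to compound 4 (0.54 log units; beyond the scatter), a step beyond the usual scatter whose full size stays unknown, as compound 4 gave a limit of the assay and not a number. The same kind of change on the core of compound 1 cannot be read, because neither compound of that pair gave a number: the limit of > 50000 nM in this assay, at which 3 of the 4 values shown sit. The series therefore holds one readable case of this change, on one core, and it shows neither that the step carries over from one core to another nor that it fails to, since the pair on the other core is compatible with a step of any size or direction.

Among these compounds, compound 3, at 14100 nM, is the only compound here with a number in this assay, so it remains open how the step would read on a core whose values both fall within the measurable range. The compounds shown also leave open whether an amine or a carboxylic acid in place of the hydroxyl group on the 3-hydroxyphenyl ring would give a lower or a higher number.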